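From iodo to methoxy on the shared core

A few compounds are considered here, and "the series" means these few. Any claim that something is new, unique, unknown or untested is made for them only; others in the source may bear on it.

Values in a functional assay on NCI-H522 cells (Homo sapiens) for inhibition; on this read-out higher numbers stand for weaker inhibition of growth and lower numbers for stronger inhibition of growth:
- compound 1 `NC(=O)c1cc(Cl)ccc1NC(=O)COc1ccccc1`: 3780 nM
- compound 2 `NC(=O)c1cc(I)ccc1NC(=O)COc1ccccc1`: 630 nM

Of these two, compound 2 holds the lower number, at 630 nM. The next structure, compound 3 `COc1ccc(NC(=O)COc2ccccc2)c(C(N)=O)c1`, carries methoxy in place of iodo on an aromatic carbon. Among the measured compounds shown here, only one measured step bears on this, a 6.0-fold lower number from compound 1 to compound 2 (0.78 log units; beyond the scatter), with iodo in place of chloro, and no other methoxy compound has been measured. Resting on that single step, a move of similar size toward a higher number is expected in this assay. The expected step is a 4.4-fold higher number from compound 2 to compound 3 (0.65 log units; beyond the scatter). For compound 3 the estimate is 2800 nM, with an expected range from 900 nM to 8000 nM.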

Compound 3, concentration for 50% growth inhibition: 1190 nM
For compound 3 the middle estimate is 2.4-fold (0.37 log units) above the measured one; the range from low to high includes it.
By their numbers in this assay, from the lowest: compounds 2 and 3 (each within the scatter of the next); then compound 1.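

In this assay, methoxy on this aromatic carbon, para to a large group, lies within the scatter of iodo (a 1.9-fold higher number from compound 2 to compound 3 (0.28 log units; within the scatter)), while it remains beyond the scatter of chloro (a 3.2-fold lower number from compound 1 to compound 3 (0.50 log units; beyond the scatter)). The lower numbers at this position are therefore not confined to iodo, and they extend to a group that brings a hydrogen-bond acceptor. No measurement at hand accounts for this result. The compounds shown leave open how an amine, a carboxylic acid or a longer chain such as butoxy would fare at this position.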